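Amide to Urea: Expecting Compound 4

A few compounds are considered here, and "the series" means these few. Any claim that something is new, unique, unknown or untested is made for them only; others in the source may bear on it.

Measured so far in a functional assay on HOP-92 cells (Homo sapiens) for inhibition, read by sulforhodamine B assay, with a stated time of 48 h; on this read-out lower numbers stand for stronger inhibition of growth and higher numbers for weaker inhibition of growth:
Compound 1, `COc1cc(-c2nn(-c3cccc(NC(=O)c4ccc(Cl)c(C(F)(F)F)c4)c3)cc2-c2ccncc2)ccc1Cl`, gives 3230 nM.
Compound 2, `COc1cc(-c2nn(-c3cccc(NC(=O)c4cccc(C(F)(F)F)c4)c3)cc2-c2ccncc2)ccc1Cl`, gives 3120 nM.
Compound 3, `O=C(Nc1cccc(-n2cc(-c3ccncc3)c(-c3ccc(Cl)c(O)c3)n2)c1)Nc1cc(C(F)(F)F)cc(C(F)(F)F)c1`, gives 1750 nM.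

Compound 1 stands highest of the three numbers. Compound 2 is nearest: a 1.0-fold lower number from compound 1 to compound 2 (0.02 log units; within the scatter), arising from hydrogen in place of chloro on an aromatic carbon. Compound 3 is furthest, yet its value and that of compound 1 lie within the scatter of each other, and compound 3 differs from compound 1 in more than one place.

Compound 4, `COc1cc(-c2nn(-c3cccc(NC(=O)Nc4ccc(Cl)c(Cl)c4)c3)cc2-c2ccncc2)ccc1Cl`, is reached from compound 1 by the change ((3,4-dichlorophenyl)amino in place of 4-chloro-3-(trifluoromethyl)phenyl on a carbonyl carbon). Going by the values given here, no measured step touches the carbonyl carbon; the only step, from compound 1 to compound 2, concerns a chloro elsewhere and stays within the scatter. Compound 3, the one other urea, gives no step beyond the scatter from compound 1 either. Compound 4 is therefore expected to show a step of about a 1.5-fold lower number from compound 1 to compound 4 (0.17 log units; within the scatter), not clearly beyond the scatter. The estimate for compound 4 is 2200 nM, with a range from 700 nM to 7000 nM.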

Compound 4, concentration for total growth inhibition: 1470 nM
Compound 4: the middle estimate sits 1.5-fold (0.18 log units) above what was measured; measured number inside the range.
By their numbers in this assay, from the lowest: compounds 4, 3, 2 and 1 (each within the scatter of the next, the first and the last beyond it).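

Going by these compounds alone, at the carbonyl carbon, replacing the aryl group with (3,4-dichlorophenyl)amino gives the first single change to pass the scatter in this assay: a 2.2-fold lower number from compound 1 to compound 4 (0.34 log units; beyond the scatter) and a 2.1-fold lower number from compound 2 to compound 4 (0.33 log units; beyond the scatter) are both modest and close in size. The earlier step of a 1.0-fold lower number from compound 1 to compound 2 (0.02 log units; within the scatter) stayed within the scatter, and the new change reads much the same from either amide, compound 1 or compound 2. Nothing available explains the step.

The change adds the amino nitrogen and alters the ring substituents at once, and no compound shown separates the two, so the share of each in the step stays open. Also open, as far as these compounds go, is how the urea would read with a carboxylic acid or a morpholine on that ring in place of the two chloro groups.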